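The compounds below may be only part of what the source reports. "The series", "measured", "known", "first", "only" and "open" are said of these compounds alone.

Within the data shown here, compound 3 `O=C(NO)c1ccc(/C=C/c2ccnc(-c3cccc(CO)c3)c2)cc1` gives 34 nM in an assay on isolated protein for inhibition of protein deacetylase HDAC6 (Homo sapiens), read by fluorescence, with a stated time of 15 min (on this read-out higher numbers stand for weaker inhibition and lower numbers for stronger inhibition), the lowest of the three numbers known here. Compound 2 `O=C(NO)c1ccc(/C=C/c2ccnc(-c3cc(F)ccc3O)c2)cc1` gives 130 nM in this assay, and compound 1 `O=C(NO)c1cccc(/C=C/c2ccnc(-c3ccccc3O)c2)c1` gives 390 nM. Compound 4 `COc1ccc(-c2cc(/C=C/c3ccc(C(=O)NO)cc3)ccn2)cc1` differs from compound 3 in one place: 4-methoxyphenyl in place of 3-(hydroxymethyl)phenyl on an aromatic carbon. Among the measured compounds shown here, the only measured step that bears on this place is a 3.8-fold lower number from compound 2 to compound 3 (0.58 log units; beyond the scatter), and the present change again exchanges the whole aryl group there. For the measured compounds named here, no measured pair sets the methoxy against the hydroxymethyl, so the account leans on that single step and on the spread of the three numbers. For compound 4 the expected step is a 1.9-fold higher number from compound 3 to compound 4 (0.28 log units; within the scatter), a modest rise in the number. Compound 4 is therefore estimated at 65 nM, within 20 nM to 220 nM.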

Compound 4, half-maximal inhibitory concentration: 110 nM
Estimate against measurement, compound 4: 1.7-fold (0.23 log units) below; the range from low to high includes it.
By their numbers in this assay, from the lowest: compound 3; then compounds 4 and 2 (each within the scatter of the next); then compound 1.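

In this assay the exchange of 3-(hydroxymethyl)phenyl for 4-methoxyphenyl, next to the ring nitrogen, gives a 3.2-fold higher number from compound 3 to compound 4 (0.51 log units; beyond the scatter) even though the two groups hold the same atoms, joined differently. The 4-methoxyphenyl and 5-fluoro-2-hydroxyphenyl groups are not told apart, as a 1.2-fold lower number from compound 2 to compound 4 (0.07 log units; within the scatter) stays within the scatter, so among these three groups only 3-(hydroxymethyl)phenyl stands apart. No measurement here accounts for this gap. From the compounds shown here alone, whether the hydroxymethyl itself or its place on the ring matters stays open, and 3-methoxyphenyl or 4-(hydroxymethyl)phenyl would separate the two. Going by these compounds, what an aminomethyl or carboxylic acid group would do there also stays open.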